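From 5-methylpyridin-2-yl to pyridin-2-yl in compound 1

The source may hold more compounds than are shown below. What is called first, only, known or untested is meant among the compounds shown, and "the series" means these compounds.

In a physicochemical assay for lipophilicity, read by HPLC, at pH 7.4 (on this read-out lower numbers stand for lower lipophilicity and higher numbers for higher lipophilicity), compound 1 (`Cc1ccc([C@@H](C)Oc2cc3onc(CCC(=O)O)c3cc2Cl)nc1`) gives 2.42 and compound 2 (`O=C(O)CCn1c(=O)oc2cc(OCc3ccccc3)c(Cl)cc21`) gives 2.71 as its value, the two lying within the usual scatter of each other. For compound 3 (`COc1cc2oc(=O)n(CCC(=O)O)c2cc1Cl`) the entry reads "not determined" (no result reported) with no number, so compound 1 has a single numerical neighbour.

Compound 4 (`C[C@@H](Oc1cc2onc(CCC(=O)O)c2cc1Cl)c1ccccn1`) awaits measurement. Its difference from compound 1 is hydrogen in place of methyl on an aromatic carbon in full: hydrogen in place of methyl on an aromatic carbon. Within the data shown here, no measured pair isolates this change, so the expectation rests on the structural change alone. In this assay a modest downward step is expected, near the edge of the scatter. The estimated step is a number 0.37 log units lower from compound 1 to compound 4 (beyond the scatter) in size. For compound 4 the estimated value is 2.05 with an expected range (from 1.75 to 2.35).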

Compound 4, distribution coefficient: 1.99
The estimate for compound 4 lay 0.06 log units above the measured number; measured number inside the range.
By their numbers in this assay, from the lowest: compound 4; then compounds 1 and 2 (each within the scatter of the next).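

In this assay, hydrogen in place of methyl on an aromatic carbon, two atoms from the ring nitrogen, gives a number 0.43 log units lower from compound 1 to compound 4 (beyond the scatter). Among these compounds, this is the first step that isolates a single change, so this position on the pyridin-2-yl group can now be read directly. No measurement shown gives a cause for the step.

As far as these compounds go, whether an amine or a longer alkyl chain at this position would shift the number in the same direction remains open. Also open, from the compounds shown here alone, is whether this change gives a similar step on another core.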